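From compound 3 to compound 4: a ring swap on the chain

The source may report more compounds than this note shows. Statements on the series, on what has been measured and on what is new or still open speak of the compounds shown alone.

Of the compounds shown here, three have numbers so far in a physicochemical assay for lipophilicity, measured as octanol-water partition, at pH 7.4; a higher number here means a more lipophilic compound, a lower number a more polar compound. Compound 1 `Cc1ccc(Cn2c(=O)[nH]c3c(N)nc(-c4ncco4)cc32)cn1` gives 1.6. Compound 2 `Cc1cc(Cn2c(=O)[nH]c3c(N)nc(C(F)(F)F)cc32)no1` gives 2.1. Compound 3 `Cc1nc(Cn2c(=O)[nH]c3c(N)nc(C(F)(F)F)cc32)cs1` gives 2.3. Compound 3 cannot be separated from compound 2, since the gap between them stays within the scatter, while compound 1 lies lower, beyond the scatter.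

The next entry is compound 4 `COc1ccc(Cn2c(=O)[nH]c3c(N)nc(C(F)(F)F)cc32)cn1`, which carries 6-methoxypyridin-3-yl in place of 2-methyl-1,3-thiazol-4-yl on a saturated chain carbon bound to an aromatic nitrogen.

Within the data shown here, only one measured step bears on this change, and it is a number 0.20 log units higher from compound 2 to compound 3 (within the scatter). There, 2-methyl-1,3-thiazol-4-yl replaced 5-methyl-1,2-oxazol-3-yl at the same place. Among the measured compounds shown here, no measured step has 6-methoxypyridin-3-yl entering, so this single swap between two other rings is a thin guide. A step of similar small size is therefore expected in this assay, with nothing beyond the scatter and no firm direction. The estimated move is a number 0.10 log units higher from compound 3 to compound 4 (within the scatter). The value expected for compound 4 is 2.4, with an estimated range from 2 to 2.8.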

Compound 4, distribution coefficient: 2.8
For compound 4 the middle estimate is 0.40 log units below the measured one, and the stated range covers the measured number.
By their numbers in this assay, from the lowest: compound 1; then compounds 2 and 3 (each within the scatter of the next); then compound 4.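

In this assay, the group on the saturated chain carbon bound to an aromatic nitrogen can now be seen to shift the number beyond the scatter: 6-methoxypyridin-3-yl in place of 2-methyl-1,3-thiazol-4-yl gives a number 0.50 log units higher from compound 3 to compound 4 (beyond the scatter), and in place of 5-methyl-1,2-oxazol-3-yl it gives a number 0.70 log units higher from compound 2 to compound 4 (beyond the scatter). Among these compounds, the only earlier step at this place, a number 0.20 log units higher from compound 2 to compound 3 (within the scatter), could not show this, so compounds 2 and 3 remain together, with their five-membered rings, and compound 4, with its six-membered ring, stands apart from both. No measurement at hand bears on the reason for this shift.

The step changes ring size, ring hetero atoms and the substituent together, so the compounds shown cannot separate the share of the methoxy group from that of the pyridine ring, and all three steps rest on cores carrying trifluoromethyl. Still open, on these data alone, is how the number would respond to an amine or a carboxylic acid on the ring at this place, or to a longer chain linking the ring to the core.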